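Swapping an aryl group on a cytotoxic quinoline amide

The compounds below may be only part of what the source reports. "The series", "measured", "known", "first", "only" and "open" are said of these compounds alone.

Measured so far:
Compound 1, `COc1cc2c(Oc3ccc(NC(=O)c4cc(-c5ccc(C)cc5)nc5ccccc45)cc3F)ccnc2cc1OCCCN1CCC(C)CC1`: 3150 nM
Compound 2, `COc1cccc(-c2cc(C(=O)Nc3ccc(Oc4ccnc5cc(OCCCN6CCC(C)CC6)c(OC)cc45)c(F)c3)c3cc(F)ccc3n2)c1`: 1210 nM

In a functional assay on HT-29 cells (Homo sapiens) for cytotoxicity, read by MTT assay, with a stated time of 72 h (on this read-out higher numbers stand for weaker inhibition and lower numbers for stronger inhibition), compound 2 gives the lowest of the two numbers; compound 1 sits higher, and that gap lies beyond the scatter. Compound 3, `COc1cc2c(Oc3ccc(NC(=O)c4cc(-c5ccc(C)cc5)nc5ccc(F)cc45)cc3F)ccnc2cc1OCCCN1CCC(C)CC1`, keeps the core of compound 2 and carries the change (4-methylphenyl in place of 3-methoxyphenyl on an aromatic carbon). Compound 1 already carries 4-methylphenyl on an otherwise similar core, so the step from compound 2 is expected to go upward, a 1.7-fold higher number from compound 2 to compound 3 (0.24 log units; within the scatter), toward weaker inhibition. Compound 3 is therefore estimated at 2100 nM, within 800 nM to 5500 nM.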

Compound 3, half-maximal inhibitory concentration: 420 nM
Compound 3: the middle estimate sits 5.0-fold (0.70 log units) above what was measured; the measured number lies below the stated range.
By their numbers in this assay, from the lowest: compound 3; then compound 2; then compound 1.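

In this assay, the aryl group on the aromatic carbon next to the ring nitrogen clearly matters: with the fluoro kept, 4-methylphenyl in place of 3-methoxyphenyl gives a 2.9-fold lower number from compound 2 to compound 3 (0.46 log units; beyond the scatter). With 4-methylphenyl kept, fluoro in place of hydrogen gives a 7.5-fold lower number from compound 1 to compound 3 (0.88 log units; beyond the scatter), so the fluoro also counts on this core. Nothing measured here explains either step.

Still open, going by these compounds, is whether an unsubstituted phenyl, a 4-chlorophenyl or a pyridine ring at the same carbon would lower the number further. Also open, on these data alone, is whether chloro would serve in place of fluoro.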